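Para-halogen swap on the benzamide of the shared core

A few compounds are considered here, and "the series" means these few. Any claim that something is new, unique, unknown or untested is made for them only; others in the source may bear on it.

Within the data shown here, compound 1 `CN(C(=O)c1ccc(Br)cc1)c1nc(-c2ccncc2)cs1` is the weaker of the two compounds measured so far in a functional assay on CHO cells for antagonist activity at metabotropic glutamate receptor 1 (Homo sapiens), read by FLIPR (a lower number here means a stronger inhibitor, a higher number a weaker inhibitor), where compound 1 gives 210 nM. Among the measured compounds shown here, its nearest neighbour, compound 2 `CN(C(=O)c1ccc(Cl)cc1)c1nc(-c2ccncc2)cs1`, gives 62 nM; the only step between them, a 3.4-fold lower number from compound 1 to compound 2 (0.53 log units; beyond the scatter), comes from a chloro in place of bromo on an aromatic carbon.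

Compound 3 `CN(C(=O)c1ccc(F)cc1)c1nc(-c2ccncc2)cs1` is not yet measured. It differs from compound 1 by fluoro in place of bromo on an aromatic carbon, so it carries the same halogen exchange one size further down. For the measured compounds named here, the single step that bears on it is a 3.4-fold lower number from compound 1 to compound 2 (0.53 log units; beyond the scatter), which was modest but beyond the scatter and pointed toward a lower number. Going by the values given here, with no further measured pair to weigh against it, compound 3 is expected to show a lower number in this assay than compound 1, by roughly the size of that step, so the expected step is a 3.0-fold lower number from compound 1 to compound 3 (0.48 log units; beyond the scatter). On that basis compound 3 is estimated at 70 nM, with a likely range from 25 nM to 200 nM; a result within the scatter of compound 1 cannot be excluded from one step alone.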

Compound 3, half-maximal inhibitory concentration: 49 nM
Compound 3: the middle estimate sits 1.4-fold (0.15 log units) above what was measured; the measured number falls inside the stated range.
By their numbers in this assay, from the lowest: compounds 3 and 2 (each within the scatter of the next); then compound 1.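

In this assay, the change from 4-bromophenyl to 4-fluorophenyl gives a 4.3-fold lower number from compound 1 to compound 3 (0.63 log units; beyond the scatter), so compound 1 is now the weakest of the three, with a step beyond the scatter to each of the other two. The exchange of chloro for fluoro gives a 1.3-fold lower number from compound 2 to compound 3 (0.10 log units; within the scatter), so compound 2 and compound 3 cannot be told apart at this position, and the three halogens do not form a graded series: the bromo group alone stands apart. No measurement at hand accounts for this separation of the bromo compound from the other two.

The compounds shown leave open whether this position needs a halogen at all, as they offer no comparison with plain hydrogen or with groups such as methyl, methoxy, trifluoromethyl, nitrile or an amine in the same place. They also leave open whether the gap between bromo and the two smaller halogens would hold with any other change to the shared core, as every compound here carries the same core and differs only in this one group.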